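Formyl removal on the diaryl ether series

A few compounds are considered here, and "the series" means these few. Any claim that something is new, unique, unknown or untested is made for them only; others in the source may bear on it.

Measured so far:
- compound 1 `C=CCc1cc(C=O)c(OCC(=O)OCC)c(-c2ccc(OCC(=O)OCC)c(CC=C)c2)c1`: 26100 nM
- compound 2 `C=CCc1ccc(OCC(=O)OCC)c(-c2ccc(OCC(=O)OCC)c(CC=C)c2)c1`: a limit of the assay, > 91300 nM
- compound 3 `C=CCc1cc(C=O)c(OCC)c(-c2ccc(OCC)c(CC=C)c2)c1`: 31900 nM

In a functional assay on Lewis lung carcinoma cells (Mus musculus) for antiproliferative activity, read by MTT assay, with a stated time of 24 h (on this read-out higher numbers stand for weaker inhibition and lower numbers for stronger inhibition), compound 1 gives 26100 nM. For compound 2 only a limit is recorded, > 91300 nM. The step of an at least 3.4-fold higher number from compound 1 to compound 2 (0.54 log units; beyond the scatter) follows the change (hydrogen in place of formyl on an aromatic carbon). Compound 3 gives 31900 nM, nearest to compound 1 and within the scatter of it; the difference between the two cores is not broken down here.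

Compound 4 `C=CCc1ccc(OCC)c(-c2ccc(OCC)c(CC=C)c2)c1` is yet to be measured. It differs from compound 3 by hydrogen in place of formyl on an aromatic carbon. The surroundings differ: here the site is ortho to an ethoxy group, whereas in the earlier pair it was ortho to a (ethoxycarbonyl)methoxy group, so this is the same kind of change, not the same one. The earlier pair gave an at least 3.4-fold higher number from compound 1 to compound 2 (0.54 log units; beyond the scatter). A step of the same kind is expected here, namely a 3.1-fold higher number from compound 3 to compound 4 (0.50 log units; beyond the scatter), resting on that single earlier pair. The estimate for compound 4 is 100000 nM, with a fair chance that, as for compound 2 (the limit of > 91300 nM in this assay, at which 1 of the 3 values shown sits), only a limit is returned.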

Compound 4, half-maximal inhibitory concentration: > 124000 nM
Compound 4 ended at the assay's limit (the forecaster's own chance of this, stated with the estimate: 55%); middle value at least 1.2-fold (0.09 log units) away from the limit.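

In this assay, hydrogen in place of formyl on an aromatic carbon again weakens inhibition, now on the core of compound 3, with an at least 3.8-fold higher number from compound 3 to compound 4 (0.58 log units; beyond the scatter). Set side by side, the two steps run the same way on both cores: the same change on two cores in this assay, an at least 3.4-fold higher number (0.54 log units; beyond the scatter) from compound 1 to compound 2 and an at least 3.8-fold higher number (0.58 log units; beyond the scatter) from compound 3 to compound 4; the limit leaves it open whether they differ. Going by these compounds, compound 2 and compound 4 are recorded only as limits, so the true size of the step on either core stays unknown, and two cores make no rule for the wider series.

Still open, on these data alone, is whether a group other than formyl on that aromatic carbon, such as a nitrile, a carboxylic acid or an amine, would keep the values seen with formyl. Also open, as far as these compounds go, is how the step would run with a longer chain in place of the allyl groups.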